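Thiourea with isopropyl in place of benzyl

A few compounds are considered here, and "the series" means these few. Any claim that something is new, unique, unknown or untested is made for them only; others in the source may bear on it.

Measured compounds:
compound 1, `CC(C)NC(=O)NC1CC(C)(C)Oc2ccc(Cl)cc21`, > 100000 nM
compound 2, `CCOC(=O)NC1CC(C)(C)Oc2ccc(Cl)cc21`, "not determined" (no result reported)
compound 3, `CC1(C)CC(NC(=S)NCc2ccccc2)c2cc(Cl)ccc2O1`, 99000 nM

Three compounds share one core and were tested in a functional assay on T98G cells (Homo sapiens) for inhibition, read by MTT assay, with a stated time of 72 h; on this read-out higher numbers stand for weaker inhibition and lower numbers for stronger inhibition. Compound 1 gives only a limit there, > 100000 nM, which is the limit of the read-out (the limit of > 100000 nM in this assay, at which 1 of the 3 values shown sits). For compound 2 the entry reads "not determined" (no result reported), so it contributes no number. Within the data shown here, compound 3 is therefore the only one with a measured value, 99000 nM, and it stands alone in this assay, with no step between measured compounds to set beside it.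

The next compound, compound 4, `CC(C)NC(=S)NC1CC(C)(C)Oc2ccc(Cl)cc21`, is built from compound 3 by isopropyl in place of benzyl on an amide-type nitrogen. Compound 1 carries the same isopropyl on a urea and reaches only its limit; compound 3 with its benzyl thiourea sits close to that same limit. Compound 4 is expected to remain weak, with an estimated step of a 1.2-fold higher number from compound 3 to compound 4 (0.08 log units; within the scatter) that lies within the scatter or slightly toward weaker inhibition. Compound 4 is estimated at 120000 nM, in a range from 50000 nM to 300000 nM.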

Compound 4, half-maximal inhibitory concentration: 91000 nM
For compound 4 the middle estimate is 1.3-fold (0.12 log units) above the measured one; measured number inside the range.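

In this assay, exchanging the benzyl on the amide-type nitrogen for isopropyl gives a 1.1-fold lower number from compound 3 to compound 4 (0.04 log units; within the scatter), so this position tolerates the loss of the aromatic ring and of several heavy atoms without a shift beyond the scatter, though both compounds remain at very high numbers. With isopropyl held in place, the urea of compound 1 and the thiourea of compound 4 give an at least 1.0-fold lower number from compound 1 to compound 4 (0.04 log units; that floor lies within the scatter), so this pair does not separate the carbonyl from the thiocarbonyl. Compound 1 stands at a limit, not at a number: the limit of > 100000 nM in this assay, at which 1 of the 4 values shown sits.

Going by these compounds, it remains open whether any group on this nitrogen can bring the number down, for example a longer chain ending in an amine or in a carboxylic acid. Also open, on these data alone, is whether replacing the chlorine on the shared core would do so.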